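This account rests on a few compounds, and the source may have more. Where it says the series, first, only, none or still open, it means among the compounds named here.

Measured so far in a functional assay for antagonist activity at transient receptor potential cation channel subfamily V member 1 (Homo sapiens), read by FLIPR and calcium flux; a lower number here means a stronger inhibitor, a higher number a weaker inhibitor:

- compound 1, `Cc1cccc(N2CCC(C(=O)Nc3ccc4c(c3)NC(=O)CO4)CC2)c1`: 490 nM
- compound 2, `O=C1COc2ccc(NC(=O)C3CCN(c4cccc(Br)c4)CC3)cc2N1`: 330 nM
- compound 3, `CC(C)c1ccccc1N1CCC(C(=O)Nc2ccc3c(c2)NC(=O)CO3)CC1`: 180 nM

Compound 3 gives the lowest number of the three. Its nearest neighbour is compound 2 at a 1.8-fold lower number from compound 2 to compound 3 (0.26 log units; within the scatter), and compound 1 sits furthest at a 2.7-fold lower number from compound 1 to compound 3 (0.43 log units; beyond the scatter).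

Compound 4, `COc1cccc(N2CCC(C(=O)Nc3ccc4c(c3)NC(=O)CO4)CC2)c1`, carries 3-methoxyphenyl in place of 2-isopropylphenyl on an amine nitrogen in a ring. Within the data shown here, the steps that bear on it are the two that replace a substituted phenyl on the same ring nitrogen: a 2.7-fold lower number from compound 1 to compound 3 (0.43 log units; beyond the scatter) and a 1.8-fold lower number from compound 2 to compound 3 (0.26 log units; within the scatter), both moving towards compound 3. Going back to a 3-substituted phenyl, a modest rise in this assay is expected, as a 2.2-fold higher number from compound 3 to compound 4 (0.35 log units; beyond the scatter). The estimate for compound 4 is 400 nM, with a range from 150 nM to 1000 nM.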

Compound 4, half-maximal inhibitory concentration: 1420 nM
Compound 4: middle estimate off by 3.6-fold (0.55 log units), on the low side; the measured number lies above the stated range.
By their numbers in this assay, from the lowest: compounds 3, 2 and 1 (each within the scatter of the next, the first and the last beyond it); then compound 4.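

In this assay, the position on the phenyl group carried by the ring amine nitrogen separates methoxy from the two other 3-substituted groups: methyl and bromo lie within the scatter of each other, yet methoxy gives a weaker inhibitor than methyl (a 2.9-fold higher number from compound 1 to compound 4 (0.46 log units; beyond the scatter)) and than bromo (a 4.3-fold higher number from compound 2 to compound 4 (0.63 log units; beyond the scatter)). The widest gap in the series now runs to the 2-isopropylphenyl group (a 7.9-fold higher number from compound 3 to compound 4 (0.90 log units; beyond the scatter)), making compound 4 the weakest of the four. No measurement offered here accounts for the methoxy result.

The step from compound 3 changes both the group and its place on the phenyl, and these remain unseparated. From the compounds shown here alone, it also remains open whether an ethoxy or hydroxy group would follow methoxy, or chloro would follow bromo.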